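Pyridin-4-yl in place of 4-fluorophenyl

A few compounds are considered here, and "the series" means these few. Any claim that something is new, unique, unknown or untested is made for them only; others in the source may bear on it.

compound 1 `COc1cc(/N=C/c2cccs2)ccc1-c1cnco1` gives > 100000 nM as a limit
compound 2 `COc1cc(/N=C/c2ccc(F)cc2)ccc1-c1cnco1` gives > 100000 nM as a limit

In an ADME assay on Huh-7 cells (Homo sapiens) for cytotoxicity, read by MTT assay, with a stated time of 96 h (on this read-out higher numbers stand for lower toxicity in this test and lower numbers for higher toxicity in this test), compound 2 gives > 100000 nM as a limit and not a number. The measurements so far amount to the limit of > 100000 nM in this assay, at which 2 of the 2 values shown sit, and nothing finer. The next compound, compound 3 `COc1cc(/N=C/c2ccncc2)ccc1-c1cnco1`, carries one change: pyridin-4-yl in place of 4-fluorophenyl on a carbon with a double bond to nitrogen and the rest stays the same. Among the compounds with values here, the one measured step at this place, a step that the two limits leave unreadable from compound 1 to compound 2, has no size that can be read, and it shows no sign of toxicity appearing. On that step, no change beyond the usual scatter is expected in this assay in either direction, and a limit is again the likeliest report. The expected step is a number no higher from compound 2 to compound 3 (the limit leaves the size open) in this estimate. For compound 3 the estimated value is 100000 nM with an expected range from 40000 nM to 200000 nM in this test.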

Compound 3, half-maximal cytotoxic concentration: > 100000 nM
Compound 3: a limit, no number (the forecaster's own chance of this, stated with the estimate: 75%); the middle value sits exactly at the limit.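

No step can be read between compound 1, compound 2 and compound 3, because each result in this assay is a limit and not a number: the limit of > 100000 nM in this assay, at which 3 of the 3 values shown sit.

The compounds shown leave open where each true value lies, and whether the three differ at all in this test.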